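A Dichlorophenyl Swap in a Cytotoxic Series

The source may report more compounds than this note shows. Statements on the series, on what has been measured and on what is new or still open speak of the compounds shown alone.

Of the compounds shown here, two sharing one core have been measured so far in a functional assay on A549 cells (Homo sapiens) for cytotoxicity, read by MTT assay, with a stated time of 72 h; on this read-out higher numbers stand for weaker inhibition and lower numbers for stronger inhibition. In this test, compound 1 (`COc1ccc(/C=C2\CCC/C(=C\c3cccc(OC)c3OC)C2=O)cc1OC`) gives 14400 nM, and compound 2 (`COc1ccc(/C=C2\CCC/C(=C\c3cccc(Br)c3)C2=O)cc1OC`) gives 12800 nM. Compound 2 therefore stands level with compound 1, since the two numbers lie within the usual scatter of repeated measurements and cannot be ranked.

Compound 3 (`COc1ccc(/C=C2\CCC/C(=C\c3cccc(Cl)c3Cl)C2=O)cc1OC`) has yet to be measured. It keeps the shared core of compound 2 but has 2,3-dichlorophenyl in place of 3-bromophenyl on a double-bonded chain carbon bound to a double-bonded ring carbon.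

Among the measured compounds shown here, no measured pair differs in only one place, so this assay offers no direct precedent for the size of this change. For the measured compounds named here, with compound 1 at 14400 nM and compound 2 at 12800 nM, the only guide is how close these two values lie, and no step beyond the scatter is expected in either direction. The expected change is a 1.1-fold lower number from compound 2 to compound 3 (0.03 log units; within the scatter), which stays within the scatter. Compound 3 is estimated at 12000 nM, with an expected range of 6000 nM to 24000 nM.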

Compound 3, half-maximal inhibitory concentration: > 20000 nM
Compound 3 ended at the assay's limit; the forecaster's own chance of this, stated with the estimate: 3%; middle value at least 1.6-fold (0.22 log units) from the limit.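

In this assay compound 3 gives > 20000 nM, which is a limit of the assay and not a number. Among the compounds shown here, replacing 3-bromophenyl with 2,3-dichlorophenyl on a double-bonded chain carbon bound to a double-bonded ring carbon gives the first step that can be read at this position, an at least 1.5-fold higher number from compound 2 to compound 3 (0.19 log units; that floor lies within the scatter). Only a floor is known for this step, so it shows the direction of the change but not its full size, and it does not establish a real loss of activity, with the reading cut off at one point in the set: the limit of > 20000 nM in this assay, at which 1 of the 3 values shown sits.

From the compounds shown here alone, the true value of compound 3 remains open, as does whether the step follows the added chlorine or the loss of bromine, a question that a 3-chlorophenyl group at this place could settle. Also open, going by these compounds, is how a phenyl ring carrying an amine or a carboxylic acid would read at this position.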